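A few compounds are considered here, and "the series" means these few. Any claim that something is new, unique, unknown or untested is made for them only; others in the source may bear on it.

Measured so far:
- compound 1, `O=C(O)c1ccc(-c2cnc(C(=O)CCCCCCc3ccccc3)o2)cc1`, in an assay (Rattus norvegicus) for inhibition of Fatty-acid amide hydrolase 1 (Homo sapiens) (on this read-out higher numbers stand for weaker inhibition and lower numbers for stronger inhibition), gives 60 nM
- compound 2, `O=C(CCCCCCc1ccccc1)c1ncc(-c2cc(C(F)(F)F)ccn2)o1`, in this assay gives 3.5 nM
- compound 3, `O=C(CCCCCCc1ccccc1)c1ncc(-c2cnc(C(=O)CCCCCCc3ccccc3)o2)o1`, in this assay gives 3500 nM

Among these three, compound 1 stands second highest. Its nearest neighbour is compound 2, whose number is lower by a margin beyond the scatter of repeated measurements, so compound 2 is the stronger inhibitor of the pair. Compound 3 lies furthest away, with a number higher than that of compound 1 by a margin that is also beyond the scatter, so compound 3 is the weaker inhibitor of that pair.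

The next compound, compound 4, `CNC(=O)c1cnc(C(=O)CCCCCCc2ccccc2)o1`, has not yet been measured. Relative to compound 1 it differs in one place: methylcarbamoyl in place of 4-carboxyphenyl on an aromatic carbon. The group that leaves carries an aromatic ring; the group that enters carries none and is smaller by the count given. Among the measured compounds shown here, no pair of measured compounds shows this exact change, so the size of the step cannot be read from the data.

The expectation is that compound 4 gives a higher number than compound 1 in this assay, meaning weaker inhibition, with the step of a 6.7-fold higher number from compound 1 to compound 4 (0.82 log units; beyond the scatter). On that basis compound 4 is estimated at 400 nM, within a range from 80 nM to 2000 nM.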

Compound 4, inhibition constant: 7 nM
Compound 4: the middle estimate sits 57-fold (1.76 log units) above what was measured; the whole stated range lies above it.
By their numbers in this assay, from the lowest: compounds 2 and 4 (each within the scatter of the next); then compound 1; then compound 3.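

In this assay, putting methylcarbamoyl in place of 4-carboxyphenyl on the aromatic carbon next to the ring oxygen gives an 8.6-fold lower number from compound 1 to compound 4 (0.93 log units; beyond the scatter) and so moves the result towards stronger inhibition. This shows that an aromatic ring in the group at this position is not required for strong inhibition, since the smaller entering group has no ring at all, and that a large part of the 4-carboxyphenyl group can go without any loss. The two groups have the same counts of hydrogen-bond donors and acceptors, so those counts do not distinguish them, and no supporting measurement is available to explain the step.

On these data alone, this single change removes the carbon-only aromatic ring and replaces the carboxylic acid with an amide at the same time, so the contribution of each remains open; a carboxylic acid placed directly on the same ring carbon, or a phenyl ring carrying the methylcarbamoyl group, would separate them. As far as these compounds go, the role of the methyl group on the amide is also open, and a plain carboxamide or an amide with a longer chain would test it.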